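The source may hold more compounds than are shown below. What is called first, only, known or untested is meant among the compounds shown, and "the series" means these compounds.

Measured in an ADME assay on the whole organism (Rattus norvegicus) for pharmacokinetics, at a dose of 1 mg/kg by the intravenous route; on this read-out higher numbers stand for wider distribution into tissues and lower numbers for narrower distribution:
- Compound 1 `COc1ccc(F)cc1-c1ccnc2[nH]c(C3=CCN([C@H]4CC[C@H](C(=O)O)CC4)CC3)cc12`: 1.9 L/kg
- Compound 2 `COc1ccc(F)cc1-c1ccnc2[nH]c(C3=CCN([C@H]4CC[C@@H](C(=O)O)CC4)CC3)cc12`: 4.7 L/kg
- Compound 3 `COc1ccc(F)cc1-c1c(F)cnc2[nH]c(C3=CCN([C@H]4CC[C@H](C(=O)O)CC4)CC3)cc12`: 2.7 L/kg

At 2.7 L/kg, compound 3 lies within the scatter of both compound 1 and compound 2. The next compound, compound 4 `COc1ccc(F)cc1-c1c(F)cnc2[nH]c(C3=CCN([C@H]4CC[C@@H](C(=O)O)CC4)CC3)cc12`, is related to compound 3 as follows: the two compounds have the same atoms and bonds and differ only in configuration as drawn: 2 of 2 stereo elements differ (all stereocentres are inverted: mirror images); a stereocentre at a saturated ring carbon is drawn r in compound 3 and s in compound 4; a stereocentre at a saturated ring carbon is drawn r in compound 3 and s in compound 4. No atoms leave or enter, and only the drawn configuration at the saturated ring carbons changes.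

Going by the values given here, the closest precedent is a 2.5-fold higher number from compound 1 to compound 2 (0.39 log units; beyond the scatter), a modest step beyond the scatter, and it is due to the fact that compounds 1 and 2 differ only in the configuration as drawn. The other measured step, a 1.4-fold higher number from compound 1 to compound 3 (0.15 log units; within the scatter), stays within the scatter and is the fluoro in place of hydrogen that compound 3 and compound 4 share. A similar rise in this assay is therefore expected, although it rests on a single pair. The estimated change is a 2.2-fold higher number from compound 3 to compound 4 (0.35 log units; beyond the scatter). Compound 4 is expected to give 6 L/kg, with an estimated range of 3.5 L/kg to 10 L/kg.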

Compound 4, volume of distribution at steady state: 2.6 L/kg
Beside the measured number, compound 4's estimate is 2.3-fold (0.36 log units) above it; the measured number lies below the stated range.
By their numbers in this assay, from the lowest: compounds 1, 4, 3 and 2 (each within the scatter of the next, the first and the last beyond it).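

In this assay, the inversion at the saturated ring carbons gave a 2.5-fold higher number from compound 1 to compound 2 (0.39 log units; beyond the scatter) on the core without the added fluoro, but with that fluoro present it gives a 1.0-fold lower number from compound 3 to compound 4 (0.02 log units; within the scatter). The inversion step therefore lies beyond the scatter on one core and within it on the other, so its rise does not carry over to every core shown. The fluoro step read on the other configuration is a 1.8-fold lower number from compound 2 to compound 4 (0.26 log units; within the scatter), and the two readings of this change do not disagree: the same change on two cores in this assay, a 1.4-fold higher number (0.15 log units; within the scatter) from compound 1 to compound 3 and a 1.8-fold lower number (0.26 log units; within the scatter) from compound 2 to compound 4, 2.6-fold (0.41 log units) apart, within the scatter of two such steps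

Going by these compounds alone, each core offers only one pair of configurations, so the result rests on two inversion steps. Going by these compounds, whether the inversion matters with an amide or a primary alcohol in place of the carboxylic acid, or with chloro in place of the added fluoro, stays open.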